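Methylating a Hydroxy Group in Two Related Cell-Growth Inhibitors

The compounds below may be only part of what the source reports. "The series", "measured", "known", "first", "only" and "open" are said of these compounds alone.

Four compounds are compared here in a functional assay on KB cells (Homo sapiens) for antiproliferative activity, read by MTT assay, with a stated time of 72 h; on this read-out higher numbers stand for weaker inhibition and lower numbers for stronger inhibition. Going by the values given here, compound 1, `COc1ccc(-c2ss/c(=N/O)c2-c2cc(OC)c(OC)c(OC)c2)cc1N`, is the most potent of the three measured so far: in this assay compound 1 gives 99 nM. Compound 3, `CO/N=c1/ssc(-c2ccc(OC)c(N)c2)c1-c1cc(OC)c(OC)c(OC)c1`, differs from compound 1 in one place, (methyl in place of hydrogen on an oxygen), and in this assay compound 3 gives 4330 nM. That single change made a 44-fold higher number from compound 1 to compound 3 (1.64 log units; beyond the scatter), so the loss of activity was large and well outside the usual scatter of repeated measurements.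

Compound 2, `COc1ccc(-c2c(-c3cc(OC)c(OC)c(OC)c3)ss/c2=N/O)cc1[N+](=O)[O-]`, carries a different core; how the core of compound 2 differs from that of compound 1 is not broken down here. In this assay compound 2 gives 5260 nM, and the numbers for compound 2 and compound 3 lie within the usual scatter of each other.

Compound 4, `CO/N=c1/ssc(-c2cc(OC)c(OC)c(OC)c2)c1-c1ccc(OC)c([N+](=O)[O-])c1`, has not yet been measured. It is related to compound 2 by methyl in place of hydrogen on an oxygen, the same change that turns compound 1 into compound 3, so the change occurs twice among these compounds. Because the earlier step was a 44-fold higher number from compound 1 to compound 3 (1.64 log units; beyond the scatter), the same change is expected to weaken compound 2 as well, though compound 2 already starts from a weak position. The expected step is an 11-fold higher number from compound 2 to compound 4 (1.06 log units; beyond the scatter). Compound 4 is therefore estimated at 60000 nM, with a likely range from 10000 nM to 300000 nM. There is also a real chance that the assay reports only a limit rather than a number for compound 4.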

Compound 4, half-maximal inhibitory concentration: > 100000 nM
Compound 4: no number, only a limit; the forecaster's own chance of this, stated with the estimate: 40%; middle value at least 1.6-fold (0.22 log units) from the limit.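

Replacing the hydrogen with a methyl on the oxygen bonded to the double-bonded nitrogen, which turns a hydroxy group into a methoxy group, also weakened inhibition on the second core, giving in this assay an at least 19-fold higher number from compound 2 to compound 4 (1.27 log units; beyond the scatter). Compound 4 gives > 100000 nM, which is a limit of the assay and not a number: the limit of > 100000 nM in this assay, at which 1 of the 4 values shown sits.

On the two cores shown, the hydroxy to methoxy change therefore goes the same way and is large each time, but this is only two cases, so it does not show that the change would behave alike on any further core, and the true size of the second step remains unknown, which means the two steps cannot be called equal or different: the same change on two cores in this assay, a 44-fold higher number (1.64 log units; beyond the scatter) from compound 1 to compound 3 and an at least 19-fold higher number (1.27 log units; beyond the scatter) from compound 2 to compound 4; the limit leaves it open whether they differ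

The compounds shown leave open whether the loss comes with methyl alone or would also follow from an ethyl group or a longer chain on the same oxygen. Going by these compounds, how the hydroxy to methoxy change would read on a core carrying a nitrile or a carboxylic acid in place of the groups seen here is equally open.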